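The source may hold more compounds than are shown below. What is called first, only, known or untested is meant among the compounds shown, and "the series" means these compounds.

In an ADME assay on S9 fraction from liver (Homo sapiens) for metabolic stability, with a stated time of 60 min (on this read-out lower numbers stand for a less stable compound and higher numbers for a more stable compound), compound 2 `CO[C@H]1CC[C@@H](CN2C(=O)CNc3ncc(-c4ccc(-c5nc[nH]n5)nc4C)nc32)CC1` stands lowest of the two numbers at 10%, while compound 1 `Cc1nc(-c2nc[nH]n2)ccc1-c1cnc2c(n1)N([C@H]1CC[C@@H](O)CC1)C(=O)CN2` gives 100%. Compound 3 `Cc1nc(-c2nc[nH]n2)ccc1-c1cnc2c(n1)N([C@H]1CC[C@H](O)CC1)C(=O)CN2` differs from compound 2 by one change: 4-hydroxycyclohexyl in place of (4-methoxycyclohexyl)methyl on an amide-type nitrogen in a ring. Going by the values given here, the only measured step that bears on this is a number 90 percentage points lower from compound 1 to compound 2 (beyond the scatter), in which the same two groups are exchanged in the opposite direction. Among the compounds with values here, this single pair points to a large rise, with no second pair to support it. The expected step is a number 70 percentage points higher from compound 2 to compound 3 (beyond the scatter). For compound 3 the estimated value is 80%, within a range of 50% to 100%.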

Compound 3, percent of the compound remaining: 97%
Estimate against measurement, compound 3: 17 percentage points below; measured number inside the range.
By their numbers in this assay, from the lowest: compound 2; then compounds 3 and 1 (each within the scatter of the next).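

In this assay, the exchange to 4-hydroxycyclohexyl on the amide-type nitrogen gives a number 87 percentage points higher from compound 2 to compound 3 (beyond the scatter), so the large gap recurs with the other drawn configuration. Configuration at the two ring stereocentres shows no readable effect here, with a number 3 percentage points lower from compound 1 to compound 3 (within the scatter), and that comparison is clean for one reason: the fact that compounds 1 and 3 differ only in the configuration as drawn

The compounds shown do not separate the methoxy group from the extra methyl link of (4-methoxycyclohexyl)methyl, as both go in one exchange. On these data alone, whether an amine or a carboxylic acid on the cyclohexyl ring would hold the read-out stays open.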